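Swapping the Aryl Group on a Fused Oxygen Core

This account rests on a few compounds, and the source may have more. Where it says the series, first, only, none or still open, it means among the compounds named here.

Of the compounds shown here, three sharing one core have been measured in a functional assay on KBVIN cells (Homo sapiens) for antiproliferative activity, read by sulforhodamine B assay, with a stated time of 3 days; on this read-out lower numbers stand for an effect already at smaller amounts and higher numbers for an effect only at larger amounts of compound. Compound 1, `CCC1=C(O)c2c(oc(-c3ccc(C(F)(F)F)cc3)cc2=O)C(CC)(CC)C1=O`, carries a trifluoromethyl-substituted phenyl ring and gives 10.4 uM. Compound 2, `CCC1=C(O)c2c(oc(-c3ccc(CBr)cc3)cc2=O)C(CC)(CC)C1=O`, gives 27.9 uM, the highest number of the three; the only single-point step shown, a 2.7-fold higher number from compound 1 to compound 2 (0.43 log units; beyond the scatter), is modest. Compound 3, `CCC1=C(O)c2c(oc(-c3ccc(OC)c(C)c3C)cc2=O)C(CC)(CC)C1=O`, whose phenyl ring carries a methoxy group and two methyl groups, gives 0.28 uM, far below compound 2.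

Compound 4, `CCC1=C(O)c2c(oc(-c3cc(C)c(O)c(C)c3)cc2=O)C(CC)(CC)C1=O`, has not yet been measured. It differs from compound 2 by 4-hydroxy-3,5-dimethylphenyl in place of 4-(bromomethyl)phenyl on an aromatic carbon. The step from compound 1 to compound 2 shows that exchanging one group on this phenyl ring moves this assay only modestly, whereas compound 3 shows that a phenyl ring bearing an oxygen substituent and two methyl groups sits at a far lower number. Since compound 4 resembles compound 3 much more closely than compound 2 does, the expectation is a large drop: a 28-fold lower number from compound 2 to compound 4 (1.45 log units; beyond the scatter). Among the compounds with values here, compound 4 is therefore estimated at 1 uM in this assay, within a range from 0.2 uM to 6 uM, the width reflecting that a hydroxy group replacing a methoxy group has no measured precedent here.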

Compound 4, concentration for half-maximal effect: 8.9 uM
The estimate for compound 4 lay 8.9-fold (0.95 log units) below the measured number; measured number outside the range, above it.
By their numbers in this assay, from the lowest: compound 3; then compounds 4 and 1 (each within the scatter of the next); then compound 2.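

In this assay the exchange at this position gives a 3.1-fold lower number from compound 2 to compound 4 (0.50 log units; beyond the scatter), so a phenyl ring with a hydroxy group and two methyl groups shifts the number only modestly, much like the earlier exchange of one group on that ring. Compound 4 at 8.9 uM and compound 1 at 10.4 uM lie within the usual scatter of each other, even though 4-hydroxy-3,5-dimethylphenyl brings a hydrogen-bond donor and the trifluoromethyl-substituted ring of compound 1 has no hydroxy group. An oxygen substituent and two methyl groups on this ring are therefore not enough on their own to give a low number, since compound 4 stays well above compound 3 at 0.28 uM, whose ring differs in both the oxygen group and the arrangement of its substituents.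

Nothing measured here offers an explanation for this result. On these data alone, it remains open whether a methoxy group in place of the hydroxy of compound 4 would close the gap to compound 3, and how an amine or a carboxylic acid on this phenyl ring would behave.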